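Exchanging the aryl group on the shared core of compound 1

This account rests on a few compounds, and the source may have more. Where it says the series, first, only, none or still open, it means among the compounds named here.

The series rests on a shared core bearing an aryl group on a nitrogen on an aromatic ring. Compound 1 `CC(C)c1ccc(Nc2ccc3c(OCCCN4CCN(C)CC4)cccc3n2)cc1` carries a 4-isopropylphenyl there, and in a functional assay on LOX IMVI cells (Homo sapiens) for inhibition, read by sulforhodamine B assay, with a stated time of 48 h (on this read-out higher numbers stand for weaker inhibition of growth and lower numbers for stronger inhibition of growth), compound 1 gives 1860 nM, the highest of the three numbers measured. Compound 2 `CN1CCN(CCCOc2cccc3nc(Nc4ccc(F)c(F)c4)ccc23)CC1` gives 1030 nM and compound 3 `CN1CCN(CCCOc2cccc3nc(Nc4cccc(Cl)c4)ccc23)CC1` gives 1680 nM. Both sit close to compound 1: the step of a 1.8-fold lower number from compound 1 to compound 2 (0.26 log units; within the scatter) and the step of a 1.1-fold lower number from compound 1 to compound 3 (0.04 log units; within the scatter) are each within the scatter, as is the step of a 1.6-fold higher number from compound 2 to compound 3 (0.21 log units; within the scatter) between the two halogenated analogues.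

Compound 4 `CN1CCN(CCCOc2cccc3nc(Nc4ccc(Cl)c(C(F)(F)F)c4)ccc23)CC1` has not yet been measured. It differs from compound 1 in one place: 4-chloro-3-(trifluoromethyl)phenyl in place of 4-isopropylphenyl on a nitrogen on an aromatic ring. Going by the values given here, the steps that bear on this change are those from compound 1 to compound 2 and from compound 1 to compound 3, both of which replace the 4-isopropylphenyl with a halogenated phenyl and both of which stay within the scatter. On that basis compound 4 is expected to land near compound 1, with a step of a 1.3-fold lower number from compound 1 to compound 4 (0.12 log units; within the scatter) that is not expected to exceed the scatter. The estimate for compound 4 in this assay is 1400 nM, with a range from 600 nM to 3300 nM.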

Compound 4, concentration for 50% growth inhibition: 1560 nM
The estimate for compound 4 lay 1.1-fold (0.05 log units) below the measured number; low and high end bracket the measured number.
By their numbers in this assay, from the lowest: compounds 2, 4, 3 and 1 (each within the scatter of the next).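

With 4-chloro-3-(trifluoromethyl)phenyl on a nitrogen on an aromatic ring, the entering group has 11 heavy atoms where the 4-isopropylphenyl has 9 and brings chlorine and fluorine together, yet this assay records only a 1.2-fold lower number from compound 1 to compound 4 (0.08 log units; within the scatter). The comparisons with the two other halogenated analogues read the same way, with a 1.1-fold lower number from compound 3 to compound 4 (0.03 log units; within the scatter) and a 1.5-fold higher number from compound 2 to compound 4 (0.18 log units; within the scatter), so compound 4 extends the earlier picture: all four aryl groups shown cannot be told apart at this position in this read-out, and no compound goes against that. No information is available that would account for this flat response.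

As far as these compounds go, all four groups are phenyl rings carrying only an alkyl group or halogens, so it remains open whether a phenyl ring bearing an amine or a carboxylic acid, or a pyridyl ring in its place, would move the number beyond the scatter. Also open, from the compounds shown here alone, is whether a bare phenyl group, with no substituent at all, would fall with these four compounds.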